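Bromo Replaces Methoxy on the Fluorinated Pyrazolone Amide

The source may report more compounds than this note shows. Statements on the series, on what has been measured and on what is new or still open speak of the compounds shown alone.

Of the compounds shown here, three built on the same core have been measured in a functional assay on HepG2 cells (Homo sapiens) for cytotoxicity, read by MTT assay, with a stated time of 72 h; on this read-out higher numbers stand for weaker inhibition and lower numbers for stronger inhibition. Compound 1 `O=C(Nc1ccc(Oc2ccnc3[nH]ccc23)cc1)c1nn(-c2ccc(Br)cc2)ccc1=O` carries a bromo on its outer phenyl ring and no fluoro on the central ring; in this assay compound 1 gives 4280 nM. Compound 2 `O=C(Nc1ccc(Oc2ccnc3[nH]ccc23)c(F)c1)c1nn(-c2ccc(Cl)cc2)ccc1=O` adds a fluoro to the central ring and carries a chloro outside. Compound 2 reaches only the limit of this assay, > 60000 nM. Compound 3 `COc1ccc(-n2ccc(=O)c(C(=O)Nc3ccc(Oc4ccnc5[nH]ccc45)c(F)c3)n2)cc1` likewise carries the fluoro, with a methoxy outside. Compound 3 also reaches only the limit, > 60000 nM. The step that the two limits leave unreadable from compound 2 to compound 3 therefore cannot be read, since (the limit of > 60000 nM in this assay, at which 2 of the 3 values shown sit).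

Compound 4 `O=C(Nc1ccc(Oc2ccnc3[nH]ccc23)c(F)c1)c1nn(-c2ccc(Br)cc2)ccc1=O` differs from compound 3 in one place: bromo in place of methoxy on an aromatic carbon. Going by the values given here, no measured step reads the effect of this change, and the two limits leave compound 3 itself unplaced beyond the edge of this assay. Compound 1 shows that a bromo outer ring without the fluoro is compatible with a measurable value. Compound 4 is therefore expected to fall at or just inside the limit, with an estimate of 40000 nM spanning 8000 nM to 120000 nM. The step that this estimate would mean, an at least 1.5-fold lower number from compound 3 to compound 4 (0.17 log units; that floor lies within the scatter), is expected to read as a gain, though the limit on compound 3 makes its true size uncertain.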

Compound 4, half-maximal inhibitory concentration: 68000 nM
The estimate for compound 4 lay 1.7-fold (0.23 log units) below the measured number; the range from low to high includes it.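

With the 4-bromophenyl group held constant, compounds 1 and 4 give the first readable measure of the fluoro in this assay: fluoro in place of hydrogen on an aromatic carbon gives a 16-fold higher number from compound 1 to compound 4 (1.20 log units; beyond the scatter). The earlier compounds shown here could not show this, as compound 2 and compound 3 each differ from compound 1 in two places, so the fluoro could not be separated from the change of outer group. The exchange of outer group itself remains unresolved, and the steps to compound 4 from compound 2 and from compound 3 cannot be read because each starts from a value that is a limit and not a number: the limit of > 60000 nM in this assay, at which 2 of the 4 values shown sit.

The compounds shown leave open whether the fluoro step would have a similar size with a 4-chlorophenyl or 4-methoxyphenyl group in place of the 4-bromophenyl group, since only the bromo series gives a pair that differs at the fluoro alone. They also leave open whether an amine or a carboxylic acid on that outer ring would give a number well clear of the limit in the presence of the fluoro.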